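The source may hold more compounds than are shown below. What is called first, only, known or untested is meant among the compounds shown, and "the series" means these compounds.

Series of aryl thioureas bearing a five-carbon phenylalkoxy tail. Compound 1 `NC(=S)Nc1ccc(OCCCCCc2ccccc2)cc1` and compound 2 `CCNC(=S)Nc1cccc(OCCCCCc2ccccc2)c1` have been run in an ADME assay on Ava5 cells (Homo sapiens) for cytotoxicity; a higher number here means that more compound is tolerated, a lower number that less compound is tolerated. Compound 1 gives 10000 nM in this assay. For compound 2 this assay returns only a limit, > 50000 nM, so no number is known for it; this is the limit of > 50000 nM in this assay, at which 1 of the 2 values shown sits. The two compounds differ at more than one place, so their values are stated side by side and nothing further is read from the pair.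

Compound 3 `S=C(NCc1ccccc1)Nc1cccc(OCCCCCc2ccccc2)c1` remains to be measured. It differs from compound 2 by phenyl in place of methyl on a saturated chain carbon bound to an amide-type nitrogen. Within the data shown here, with no comparable step available among the measured compounds, the step from compound 2 to compound 3 in this assay is expected to be small, if any, with cytotoxicity likely either unchanged or somewhat increased relative to the limit of compound 2. On that basis compound 3 is estimated at 40000 nM, with a range from 15000 nM to 100000 nM. The step that this estimate would mean is expected to be an at least 1.2-fold lower number from compound 2 to compound 3 (0.09 log units; that floor lies within the scatter).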

Compound 3, half-maximal cytotoxic concentration: 32000 nM
The estimate for compound 3 lay 1.3-fold (0.10 log units) above the measured number; the measured number falls inside the stated range.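

Phenyl in place of methyl on a saturated chain carbon bound to an amide-type nitrogen gives the first step in the series that can be read at a single place: in this assay there is an at least 1.5-fold lower number from compound 2 to compound 3 (0.19 log units; that floor lies within the scatter). With this change, compound 3 gives a measured number, 32000 nM, so the benzylamino form has a defined value in this assay. On these data alone, for compound 2, > 50000 nM is a limit and not a number, so only a floor can be set on the step, and its true size remains unknown: the limit of > 50000 nM in this assay, at which 1 of the 3 values shown sits.

Still open, as far as these compounds go, is how far this step depends on the aromatic ring, which a cyclohexyl group at the same place could test. A longer chain ending in phenyl, or a carboxylic acid on that chain, would show whether the number moves beyond the scatter.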